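The compounds below may be only part of what the source reports. "The series", "measured", "known", "first", "only" and "open" are said of these compounds alone.

Among the compounds with values here, compound 1 `O=C(Nc1ccccc1)c1c(NO)cc(-c2ccccc2)oc1=O` was tested in an ADME assay on Huh-7 cells (Homo sapiens) for cytotoxicity, read by a luciferase reporter and WST assay, with a stated time of 3 days (a higher number here means that more compound is tolerated, a lower number that less compound is tolerated), and gave 11600 nM, the lower of the two numbers measured so far. Compound 2 `COc1ccc(-c2cc(NO)c(C(=O)Nc3ccccc3)c(=O)o2)cc1` gave 16200 nM, so the step of a 1.4-fold higher number from compound 1 to compound 2 (0.15 log units; within the scatter) came with methoxy in place of hydrogen on an aromatic carbon. Compound 3 `COc1ccc(NC(=O)c2c(NO)cc(-c3ccccc3)oc2=O)cc1` differs from compound 1 by methoxy in place of hydrogen on an aromatic carbon, the same kind of change set at another place. Within the data shown here, the only comparable step is a 1.4-fold higher number from compound 1 to compound 2 (0.15 log units; within the scatter). Compound 3 is therefore expected to show a 1.1-fold higher number from compound 1 to compound 3 (0.05 log units; within the scatter), nothing beyond the scatter. The estimate for compound 3 is 13000 nM, with a range from 6500 nM to 26000 nM.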

Compound 3, half-maximal cytotoxic concentration: > 20000 nM
Compound 3: a limit, no number; the forecaster's own chance of this, stated with the estimate: 10%; at least 1.5-fold (0.18 log units) between middle value and limit.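

In this assay, compound 3 gives a limit and not a number: the limit of > 20000 nM in this assay, at which 1 of the 3 values shown sits. Replacing phenyl with 4-methoxyphenyl at this place gives an at least 1.7-fold higher number from compound 1 to compound 3 (0.23 log units; that floor lies within the scatter). This place therefore carries a methoxy with no drop in the number, although the true size of the rise stays unknown and a real gap is not shown. The compounds shown leave open how a different group at this place, such as an amine or a carboxylic acid, would change the number in this assay.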